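The compounds below may be only part of what the source reports. "The series", "measured", "known", "first", "only" and "open" are said of these compounds alone.

Notes on the series in a functional assay on B16 cells (Mus musculus) for cytotoxicity, read by MTT assay, with a stated time of 72 h; on this read-out lower numbers stand for stronger inhibition and higher numbers for weaker inhibition.

Compound 1 `COc1c(OCCCCN2CCN(C)CC2)cc(O)c2c(=O)cc(-c3ccc(C)cc3)oc12` gives 5430 nM in this assay. Compound 2 `COc1c(OCCCCN2CCN(C)CC2)cc(O)c2c(=O)cc(-c3ccc(C(F)(F)F)cc3)oc12` gives 4990 nM. Compound 3 `CN(C)CCCOc1c(OCc2ccccc2)cc(O)c2c(=O)cc(-c3ccccc3)oc12` gives 5420 nM. Compound 3 stands second highest of the three numbers, yet its distance to compound 1 and to compound 2 is within the scatter, so no order among the three is established.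

Within the data shown here, the only step between compounds differing in one place is a 1.1-fold lower number from compound 1 to compound 2 (0.04 log units; within the scatter), a change on the aryl group that says nothing about the amine end of the chain.

Compound 4 `CN1CCN(CCCOc2c(OCc3ccccc3)cc(O)c3c(=O)cc(-c4ccccc4)oc23)CC1` is not yet measured. It differs from compound 3 by 4-methylpiperazin-1-yl in place of dimethylamino on a saturated chain carbon, three bonds along the chain from an oxygen on an aromatic ring. Among the measured compounds shown here, no measured step covers this exchange; compounds 1 and 2 also contain 4-methylpiperazin-1-yl, but they differ from compound 3 in more than one place, and their numbers sit within the scatter of compound 3 anyway. The expectation is therefore no step beyond the scatter, a 1.0-fold lower number from compound 3 to compound 4 (0.00 log units; within the scatter). Compound 4 is estimated at 5400 nM, with a range from 2500 nM to 12000 nM.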

Compound 4, half-maximal inhibitory concentration: 3760 nM
Beside the measured number, compound 4's estimate is 1.4-fold (0.16 log units) above it; the range from low to high includes it.
By their numbers in this assay, from the lowest: compounds 4, 2, 3 and 1 (each within the scatter of the next).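

In this assay, among these compounds, the exchange at the chain end now has a measured step, a 1.4-fold lower number from compound 3 to compound 4 (0.16 log units; within the scatter), the first reading of a change in the amine on this chain. At this position, on a saturated chain carbon, three bonds along the chain from an oxygen on an aromatic ring, 4-methylpiperazin-1-yl with its 7 heavy atoms and six-membered non-aromatic ring takes the place of dimethylamino with its 3 heavy atoms without a step beyond the scatter. Nothing on hand bears on the size of this step.

As far as these compounds go, whether morpholin-4-yl, a primary amine or a carboxylic acid at the chain end would move the number beyond the scatter remains open. Also open, from the compounds shown here alone, is whether the exchange reads the same on a longer chain with the rest of compound 3 unchanged.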